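Swapping the Phenyl Amide for a Pyrimidine Amide

The source may report more compounds than this note shows. Statements on the series, on what has been measured and on what is new or still open speak of the compounds shown alone.

Compound 1 `COc1ccc2nc(C)cc(OCC(=O)Nc3cc(C)cc(C)c3)c2c1` stands second highest of the three compounds measured in a physicochemical assay for lipophilicity, read by HPLC, in phosphate buffer, measured as chromatographic lipophilicity, at pH 7.4 (on this read-out lower numbers stand for lower lipophilicity and higher numbers for higher lipophilicity), where compound 1 gives 5.64. Its nearest neighbour is compound 2 `Cc1cc(C)cc(NC(=O)COc2cc(C)nc3ccc(C)cc23)c1`, which gives 5.95; compound 3 `COc1cc2nc(C)cc(OCC(=O)Nc3cc(C)cc(C)c3)c2cc1OC` lies furthest away and gives 4.84. The step of a number 0.31 log units higher from compound 1 to compound 2 (beyond the scatter) is the smaller of the two, while a number 0.80 log units lower from compound 1 to compound 3 (beyond the scatter) is the larger. Compound 4 `COc1ccc2nc(C)cc(OCC(=O)Nc3cc(C)nc(C)n3)c2c1` differs from compound 1 by 2,6-dimethylpyrimidin-4-yl in place of 3,5-dimethylphenyl on an amide-type nitrogen. Neither measured step touches the ring on the amide-type nitrogen; both change a group on the shared core. Still, the step of a number 0.80 log units lower from compound 1 to compound 3 (beyond the scatter) shows how far one change can move this assay. For compound 4 a lowering beyond the scatter is expected, estimated as a number 1.64 log units lower from compound 1 to compound 4 (beyond the scatter). Compound 4 is therefore expected to give 4, within 3.3 to 4.7.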

Compound 4, distribution coefficient: 3.24
Compound 4: middle estimate off by 0.76 log units, on the high side; measured number below the stated range.
By their numbers in this assay, from the lowest: compound 4; then compound 3; then compound 1; then compound 2.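

Within the data shown here, the ring on the amide-type nitrogen, untouched by the earlier steps, carries the largest change yet seen in this assay: a number 2.40 log units lower from compound 1 to compound 4 (beyond the scatter) against a number 0.80 log units lower from compound 1 to compound 3 (beyond the scatter) on the shared core. The swap leaves 8 heavy atoms in the group, yet puts nitrogen into the ring and brings 2 hydrogen-bond acceptors.

Going by these compounds, whether a dimethylpyridinyl group, with a single ring nitrogen, would give part of this step stays open, as does whether the swap moves compound 2 or compound 3 as far. Nothing available accounts for the size of the step.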